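A Phenyl Added to the Methyl Amine Analogue

The source may hold more compounds than are shown below. What is called first, only, known or untested is meant among the compounds shown, and "the series" means these compounds.

Of the compounds shown here, three have been measured in an assay on membranes from brain for displacement of a labelled ligand from Neuronal acetylcholine receptor; alpha4/beta2 (Rattus norvegicus); a lower number here means a stronger inhibitor, a higher number a weaker inhibitor. Compound 1 `c1cncc(N2C[C@H]3CNC[C@H]3C2)c1` gives 0.12 nM. Compound 3 `Brc1cncc(N2C[C@H]3CNC[C@H]3C2)c1`, with a bromo in place of a hydrogen on an aromatic carbon, gives 0.06 nM; that step is a 2.0-fold lower number from compound 1 to compound 3 (0.30 log units; within the scatter). Compound 2 `CN1C[C@@H]2CN(c3cccnc3)C[C@@H]2C1`, with a methyl in place of a hydrogen on the amine nitrogen in the ring, gives 26 nM, the highest of the three numbers: the step is a 220-fold higher number from compound 1 to compound 2 (2.34 log units; beyond the scatter), and compound 3 lies further still from compound 2.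

Compound 4 `CN1C[C@@H]2CN(c3cncc(-c4ccccc4)c3)C[C@@H]2C1` keeps the methyl of compound 2 and differs from it in one place: phenyl in place of hydrogen on an aromatic carbon. For the measured compounds named here, the only measured step at that same aromatic position is the bromo of compound 3, which moved the number only within the scatter. Phenyl is a larger group than bromo, so the bromo step is an imperfect guide, but nothing measured here points to a large shift. Compound 4 is therefore expected to stay close to compound 2, with a 1.3-fold lower number from compound 2 to compound 4 (0.11 log units; within the scatter) as the estimated step, giving an estimate of 20 nM within a range of 4 nM to 100 nM.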

Compound 4, inhibition constant: 51 nM
For compound 4 the middle estimate is 2.6-fold (0.41 log units) below the measured one, within the range that was stated.
By their numbers in this assay, from the lowest: compounds 3 and 1 (each within the scatter of the next); then compounds 2 and 4 (each within the scatter of the next).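

In this assay the aromatic carbon two atoms from the ring nitrogen now carries a phenyl of 6 heavy atoms instead of a hydrogen, and the step is a 2.0-fold higher number from compound 2 to compound 4 (0.29 log units; within the scatter), so compound 2 and compound 4 cannot be told apart here. The earlier bromo step, a 2.0-fold lower number from compound 1 to compound 3 (0.30 log units; within the scatter), was read with a hydrogen on the ring amine nitrogen, whereas this one shows that a substituent at this position also stays within the scatter with the methyl on that nitrogen. Nothing available bears on the reason for this result.

From the compounds shown here alone, whether phenyl would give an equally small step with a hydrogen in place of the methyl stays open. The compounds shown also leave open how an amine or a carboxylic acid would read at this aromatic carbon.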